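Compound 4: methyl in place of 3,4-difluorophenyl, expected maximal response

A few compounds are considered here, and "the series" means these few. Any claim that something is new, unique, unknown or untested is made for them only; others in the source may bear on it.

Working notes on the series. Compound 1 `N=C(NCCCc1c[nH]cn1)NC(=O)CC(c1ccccc1)c1ccc(F)c(F)c1` gives 81% in a functional assay on cardiac atrium for agonist activity at histamine H2 receptor (Cavia porcellus); on this read-out higher numbers stand for larger maximal responses and lower numbers for smaller maximal responses. Compound 2 `N=C(NCCCc1c[nH]cn1)NC(=O)CC(c1ccc(F)c(F)c1)c1nccs1` gives 90% in this assay, and compound 3 `N=C(NCCCc1c[nH]cn1)NC(=O)CC(c1ccc(F)c(F)c1)c1ncc[nH]1` gives 100%. Compound 2 stands second highest of the three numbers: a number 9 percentage points higher from compound 1 to compound 2 (within the scatter), and a number 10 percentage points higher from compound 2 to compound 3 (within the scatter), so compound 2 is separated from neither neighbour beyond the scatter; only the outer pair differs clearly, a number 19 percentage points higher from compound 1 to compound 3 (beyond the scatter).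

Compound 4 `CC(CC(=O)NC(=N)NCCCc1c[nH]cn1)c1nccs1` differs from compound 2 in one place: methyl in place of 3,4-difluorophenyl on a saturated chain carbon bound to an aromatic carbon and a saturated chain carbon. Among the compounds with values here, no measured step bears directly on this change. All three measured steps exchange the other group on the same saturated chain carbon while the 3,4-difluorophenyl is kept, and the largest of them, a number 19 percentage points higher from compound 1 to compound 3 (beyond the scatter), is only modest. The present change removes a whole ring, which is outside what the series has varied so far, so a maximal response in this assay that is held or somewhat lowered is expected rather than raised; the expected step is a number 12 percentage points lower from compound 2 to compound 4 (beyond the scatter). Compound 4 is estimated at 78%, with a range from 58% to 98%.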

Compound 4, largest response reached (Emax), in percent of the reference or control that the assay uses: 91%
Estimate against measurement, compound 4: 13 percentage points below, and the stated range covers the measured number.
By their numbers in this assay, from the lowest: compounds 1, 2, 4 and 3 (each within the scatter of the next, the first and the last beyond it).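

In this assay the change gives a number 1 percentage points higher from compound 2 to compound 4 (within the scatter), even though 8 heavy atoms with a six-membered aromatic ring leave and a single carbon enters. The earlier compounds shown here all kept the 3,4-difluorophenyl, whereas this pair shows that, with 1,3-thiazol-2-yl as the other group, the maximal response does not depend on that ring at this saturated chain carbon bound to an aromatic carbon and a saturated chain carbon. Nothing shown here gives a reason for this result.

The compounds shown leave open whether methyl is tolerated in the same way when phenyl or 1H-imidazol-2-yl is the other group. They also leave open what a hydrogen, an ethyl, an amine or a carboxylic acid in place of the methyl would give in this assay.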